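The source may hold more compounds than are shown below. What is called first, only, known or untested is meant among the compounds shown, and "the series" means these compounds.

Compound 1 `Cc1ccc2[nH]c(-c3ccc(-c4ccc(-c5ccc(N(C)C)cc5)cc4)cc3)nc2c1` gives 6240 nM in a functional assay on KB cells (Homo sapiens) for inhibition, read by sulforhodamine B assay; a higher number here means a weaker inhibitor of growth, a lower number a stronger inhibitor of growth. Compound 2 `Cc1ccc2[nH]c(-c3ccc(-c4ccc(-c5cccc(Cl)c5)cc4)cc3)nc2c1` differs by 3-chlorophenyl in place of 4-(dimethylamino)phenyl on an aromatic carbon and gives 2260 nM; the step is a 2.8-fold lower number from compound 1 to compound 2 (0.44 log units; beyond the scatter). Compound 3 `CN(C)c1ccc(-c2ccc(-c3ccc(-c4nc5c(O)cccc5[nH]4)cc3)cc2)cc1` carries a different core, the difference being (4-hydroxy-1H-benzimidazol-2-yl in place of 5-methyl-1H-benzimidazol-2-yl on an aromatic carbon), and gives 4200 nM; the step of a 1.5-fold lower number from compound 1 to compound 3 (0.17 log units; within the scatter) shows the two cores giving numbers close to each other. Compound 4 `Oc1cccc2[nH]c(-c3ccc(-c4ccc(-c5cccc(Cl)c5)cc4)cc3)nc12` remains to be measured; it differs from compound 3 by 3-chlorophenyl in place of 4-(dimethylamino)phenyl on an aromatic carbon, the same change as from compound 1 to compound 2, on the same kind of position. Within the data shown here, the step of a 2.8-fold lower number from compound 3 to compound 4 (0.45 log units; beyond the scatter) is expected to resemble the one seen for compound 1 and compound 2, because a 2.8-fold lower number from compound 1 to compound 2 (0.44 log units; beyond the scatter) was the only observation of this change and the two cores behaved alike in compound 1 and compound 3. Compound 4 is accordingly estimated at 1500 nM, with a plausible range from 700 nM to 3500 nM.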

Compound 4, concentration for 50% growth inhibition: 2280 nM
Estimate against measurement, compound 4: 1.5-fold (0.18 log units) below; measured number inside the range.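

In this assay, 3-chlorophenyl in place of 4-(dimethylamino)phenyl on the core of compound 3 gives a 1.8-fold lower number from compound 3 to compound 4 (0.27 log units; within the scatter), so this step alone does not establish a change. Set beside the earlier step, it cannot be told apart in size: the same change on two cores in this assay, a 2.8-fold lower number (0.44 log units; beyond the scatter) from compound 1 to compound 2 and a 1.8-fold lower number (0.27 log units; within the scatter) from compound 3 to compound 4, 1.5-fold (0.18 log units) apart, within the scatter of two such steps. The change therefore carries across these two cores without a detectable difference, but two steps do not show that it would carry to any further core, and only one of them lies beyond the scatter.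

Open, on these data alone, is how the change would run on a core carrying an amine or a carboxylic acid in place of the methyl or hydroxy group. Also open, as far as these compounds go, is whether a fluorine or a methoxy group in place of the chlorine would give a similar step.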